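The compounds below may be only part of what the source reports. "The series", "measured", "known", "first", "only" and "open" are said of these compounds alone.

Four related compounds are compared here. Compound 1 `O=c1cc(-c2ccc([N+](=O)[O-])cc2)oc2cc(O)ccc12` and compound 2 `O=c1cc(-c2ccc([N+](=O)[O-])cc2)oc2c(O)c(O)ccc12` share one core; compound 3 `COc1cc(-c2cc(=O)c3ccc(O)cc3o2)cc(OC)c1OC` and compound 4 `COc1cc(-c2cc(=O)c3ccc(O)c(O)c3o2)cc(OC)c1OC` share another, and the difference between the two cores is not broken down here. All were tested in a functional assay on A549 cells (Homo sapiens) for cytotoxicity, read by MTT assay, with a stated time of 6 days; on this read-out higher numbers stand for an effect only at larger amounts of compound and lower numbers for an effect already at smaller amounts. In this assay compound 1 gives 21.8 ug/mL. Compound 2 differs from compound 1 by one change, (hydroxy in place of hydrogen on an aromatic carbon), and in this assay compound 2 gives 2.56 ug/mL. That change produced an 8.5-fold lower number from compound 1 to compound 2 (0.93 log units; beyond the scatter). For compound 3 this assay reports only a limit, > 25 ug/mL, so no number is known for it (the limit of > 25 ug/mL in this assay, at which 1 of the 3 values shown sits). Compound 4 is made from compound 3 by the same change, (hydroxy in place of hydrogen on an aromatic carbon), at a place described in the same words. Resting on the step of an 8.5-fold lower number from compound 1 to compound 2 (0.93 log units; beyond the scatter), compound 4 is expected to show an at least 4.1-fold lower number from compound 3 to compound 4 (0.61 log units; beyond the scatter) in this assay. Compound 3 has only a limit, so the starting point is uncertain and the expectation is correspondingly wide. Compound 4 is estimated at 6 ug/mL in this assay, with a likely range from 1.5 ug/mL to 25 ug/mL.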

Compound 4, concentration for half-maximal effect: 5.27 ug/mL
Beside the measured number, compound 4's estimate is 1.1-fold (0.06 log units) above it; the measured number falls inside the stated range.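

In this assay a hydroxy group in place of hydrogen goes with a lower number on both cores, and on the core of compound 3 the result is an at least 4.7-fold lower number from compound 3 to compound 4 (0.67 log units; beyond the scatter). Compound 3 is recorded only as a limit, > 25 ug/mL, and not as an exact number. These two pairs show the direction of the change carrying over from one core to the other, but they do not establish a rule for other cores or show whether the size of the step is the same on both: the same change on two cores in this assay, an 8.5-fold lower number (0.93 log units; beyond the scatter) from compound 1 to compound 2 and an at least 4.7-fold lower number (0.67 log units; beyond the scatter) from compound 3 to compound 4; the limit leaves it open whether they differ

The compounds shown have only a hydroxy group or hydrogen at this place, so it remains open how an amine or a carboxylic acid there would compare. From the compounds shown here alone, it also remains open whether the same step would appear on a third core, such as one carrying a chloro group in place of the nitro group of compound 1.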